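A few compounds are considered here, and "the series" means these few. Any claim that something is new, unique, unknown or untested is made for them only; others in the source may bear on it.

Measured so far in an ADME assay on HCT-116 cells (Homo sapiens) for cytotoxicity, read by CellTiter-Glo, with a stated time of 72 h; on this read-out lower numbers stand for stronger inhibition and higher numbers for weaker inhibition:

Compound 1 `CC1CCN(C2CCN(S(=O)(=O)c3cccnc3F)CC2)CC1`
Compound 2 `CC1CCN(C2CCN(S(=O)(=O)c3cccc(-c4ccc(Cl)cc4)c3)CC2)CC1`
Compound 3 `CCCCOc1ccc(S(=O)(=O)N2CCC(N3CCC(C)CC3)CC2)cc1`

All three share the same core and differ only in the aromatic group attached to the sulfonyl sulfur. For compound 1 this assay reports only a limit, > 10000 nM, and not a number. For compound 2 this assay likewise reports only a limit, > 5000 nM. For compound 3 the result is again a limit, > 5000 nM. So compound 1 sits at the limit of > 10000 nM in this assay, at which 1 of the 3 values shown sits, while the other two sit at the limit of > 5000 nM in this assay, at which 2 of the 3 values shown sit; none of the three has a measured value, and no compound can be ranked against another.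

Compound 4 `CC1CCN(C2CCN(S(=O)(=O)c3ccc(Cl)cc3Cl)CC2)CC1` has not yet been tested. The change from compound 1 is 2,4-dichlorophenyl in place of 2-fluoropyridin-3-yl on a sulfonyl sulfur. Among the compounds with values here, no step between measured compounds is available to guide the expectation, and nothing among the three results points toward a measurable effect in this assay. The step from compound 1 to compound 4 in this assay is therefore expected to be a step that the limit leaves unreadable from compound 1 to compound 4, that is, no change beyond the scatter. Compound 4 is estimated at 20000 nM, with a range from 5000 nM to 80000 nM, and most likely this assay will again report only a limit.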

Compound 4, half-maximal inhibitory concentration: > 5000 nM
Compound 4 ended at the assay's limit; the forecaster's own chance of this, stated with the estimate: 85%; the middle value does not contradict the limit.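

Compound 1 and compound 4 both end at limits of this assay and not at numbers, so the step between them cannot be read. The compounds shown leave open whether any aromatic group on the sulfonyl sulfur of the shared core gives a measured value in this assay, and how the four compare.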